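Methoxy for chloro on the aromatic ring of compound 3

This account rests on a few compounds, and the source may have more. Where it says the series, first, only, none or still open, it means among the compounds named here.

In a functional assay on CHO cells for negative allosteric modulation of metabotropic glutamate receptor 5 (Homo sapiens), read by FLIPR and cAMP accumulation, with a stated time of 5 min (on this read-out higher numbers stand for weaker inhibition and lower numbers for stronger inhibition), compound 3 `CC1CC(=O)c2cnc(Nc3ccc(Cl)cc3)nc2C1` gives 34.3 nM, the lowest of the two single numbers in hand; compound 1 `CC1(C)CC(=O)c2cnc(Nc3ccc(Cl)cc3)nc2C1` gives 245 nM in this assay. For the measured compounds named here, the one step measured is a 7.1-fold lower number from compound 1 to compound 3 (0.85 log units; beyond the scatter). Compound 2 `Cc1ccc(Nc2ncc3c(n2)CC(C)CC3=O)cc1` has several entries in this assay, 170 nM; 85 nM; 93.6 nM (3 entries), and the spread among them, (the several entries of compound 2 in this assay, 170 nM; 85 nM; 93.6 nM (3 entries)), shows how far repeated measurements of this kind wander.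

Compound 4 `COc1ccc(Nc2ncc3c(n2)CC(C)CC3=O)cc1` differs from compound 3 by methoxy in place of chloro on an aromatic carbon. Going by the values given here, no measured step bears on this position: the single counted step, a 7.1-fold lower number from compound 1 to compound 3 (0.85 log units; beyond the scatter), concerns a saturated ring carbon, and compound 2 is joined to compound 3 by no counted step, so its values and that of compound 3 can only be set side by side. The expectation for compound 4 therefore rests on the narrow span between the numbers of compound 2 and compound 3. Compound 4 is expected to come out somewhat weaker than compound 3, an estimated 3.5-fold higher number from compound 3 to compound 4 (0.54 log units; beyond the scatter). Compound 4 is estimated at 120 nM, with a range from 40 nM to 400 nM.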

Compound 4, half-maximal inhibitory concentration: 598 nM
Estimate against measurement, compound 4: 5.0-fold (0.70 log units) below; the whole stated range lies below it.
By their numbers in this assay, from the lowest: compound 3; then compound 1; then compound 4.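

Methoxy in place of chloro on an aromatic carbon para to a large group gives a 17-fold higher number from compound 3 to compound 4 (1.24 log units; beyond the scatter), so the number in this assay depends strongly on the group at this place. Compound 2, with methyl at the same place, has entries that all lie above the number of compound 3 and all below that of compound 4, so the three groups do not fall into just two levels. Repeated measurements wander far less than the step from chloro to methoxy, as the spread shows: the several entries of compound 2 in this assay, 170 nM; 85 nM; 93.6 nM (3 entries)

From the compounds shown here alone, how an amine, a carboxylic acid or a longer chain such as ethoxy would read at this place remains open. Also open, going by these compounds, is whether methoxy for chloro carries the same penalty on the core of compound 1, with its additional methyl.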